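Acetyl for hydrogen on the ring nitrogen of compound 2

The compounds below may be only part of what the source reports. "The series", "measured", "known", "first", "only" and "open" are said of these compounds alone.

Measured compounds:
compound 1, `CCCCCCCCn1nc2ccccc2c1OCC`, > 10000 nM
compound 2, `CC(=O)OCC(C)n1[nH]c2ccccc2c1=O`, 2120 nM

Of the compounds shown here, two have been tested in an assay on isolated protein (urine) for inhibition of Myeloperoxidase (Homo sapiens), read by spectrophotometry; on this read-out higher numbers stand for weaker inhibition and lower numbers for stronger inhibition. Compound 1, `CCCCCCCCn1nc2ccccc2c1OCC`, gives only a limit of the assay, > 10000 nM, and no number. For the measured compounds named here, the one numerical value belongs to compound 2, `CC(=O)OCC(C)n1[nH]c2ccccc2c1=O`, which in this assay reaches 2120 nM. Going by the values given here, compound 2 therefore stands as the only compound with a measured figure; the other value is a limit at which one of the two readings sits, (the limit of > 10000 nM in this assay, at which 1 of the 2 values shown sits).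

Compound 3, `CC(=O)OCC(C)n1c(=O)c2ccccc2n1C(C)=O`, has not been measured. It differs from compound 2 in one place: acetyl in place of hydrogen on an aromatic nitrogen. The newcomer keeps the whole acetoxy-bearing side chain of compound 2 and gains a second acetyl on the aromatic nitrogen of a five-membered aromatic ring with 2 nitrogen, part of a fused or bridged system of two rings.

Among the compounds with values here, no measured pair in this set shows a step of this kind, so the direction can only be estimated. Compound 3 is expected to be somewhat weaker than compound 2, a step of a 2.1-fold higher number from compound 2 to compound 3 (0.33 log units; beyond the scatter), which is estimated to fall only modestly beyond the usual scatter. For compound 3 the expected value in this assay is 4500 nM, with a range from 1200 nM to 15000 nM.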

Compound 3, half-maximal inhibitory concentration: > 10000 nM
Compound 3: only a limit was reported (the forecaster's own chance of this, stated with the estimate: 25%); middle value at least 2.2-fold (0.34 log units) away from the limit.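

In this assay, for the compounds shown here, acetyl in place of hydrogen on the aromatic nitrogen gives an at least 4.7-fold higher number from compound 2 to compound 3 (0.67 log units; beyond the scatter), the first step in this set between compounds that differ in one place. This shows that the ring nitrogen is not a neutral spot for this change: the hydrogen there cannot be swapped for acetyl without a loss of inhibition beyond the usual scatter, even though the acetoxy-bearing side chain stays the same. The step gives only a minimum size and the real loss may be larger, because compound 3 reports a limit rather than a number, and most of the readings in this small set now sit at that same limit: the limit of > 10000 nM in this assay, at which 2 of the 3 values shown sit.

Going by these compounds, what remains open is whether the loss belongs to acetyl in particular or would follow any group placed on this nitrogen, such as a small methyl or a chain ending in an amine. The compounds shown also do not say how much the acetoxy-bearing side chain itself contributes, for instance whether a plain hydroxyl in place of its acetyl ester would give a stronger or a weaker inhibitor.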